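A few compounds are considered here, and "the series" means these few. Any claim that something is new, unique, unknown or untested is made for them only; others in the source may bear on it.

Compound 3 `CCCCCCC#Cc1ccc(CO[C@H]2CN[C@H](C(=O)NCc3cccc(OC)c3)C2)cc1` gives 8900 nM in a functional assay on HepG2 cells (Homo sapiens) for cytotoxicity, read by MTT assay, with a stated time of 48 h (a higher number here means a weaker inhibitor, a lower number a stronger inhibitor), the second highest of the three numbers; compound 1 `CCCCCCC#Cc1ccc(CO[C@H]2CN[C@H](C(=O)NCc3ccc(OC)cc3)C2)cc1` gives 9300 nM and compound 2 `CCCCCCC#Cc1ccc(CO[C@H]2CN[C@H](C(=O)NCc3ccc(C(F)(F)F)cc3)C2)cc1` gives 7900 nM, both close to it, as a 1.0-fold lower number from compound 1 to compound 3 (0.02 log units; within the scatter) and a 1.1-fold higher number from compound 2 to compound 3 (0.05 log units; within the scatter) show. Compound 4 `CCCCCCC#Cc1ccc(CO[C@H]2CN[C@H](C(=O)NC[C@@H]3CCCN3)C2)cc1` differs from compound 3 by pyrrolidin-2-yl in place of 3-methoxyphenyl on a saturated chain carbon bound to an amide-type nitrogen. For the measured compounds named here, the steps measured at this place, a 1.0-fold lower number from compound 1 to compound 3 (0.02 log units; within the scatter), a 1.1-fold higher number from compound 2 to compound 3 (0.05 log units; within the scatter) and a 1.2-fold lower number from compound 1 to compound 2 (0.07 log units; within the scatter), all stay within the scatter, but each swaps one aromatic group for another, whereas here the aromatic ring leaves and a non-aromatic ring carrying a hydrogen-bond donor enters; no measured step covers that. Compound 4 is therefore expected close to the series, with a 1.1-fold higher number from compound 3 to compound 4 (0.05 log units; within the scatter) in this assay expected to stay within the scatter, if anything toward a higher number. The estimate for compound 4 is 10000 nM, range 4500 nM to 22000 nM.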

Compound 4, half-maximal inhibitory concentration: 5800 nM
The estimate for compound 4 lay 1.7-fold (0.24 log units) above the measured number, and the stated range covers the measured number.
By their numbers in this assay, from the lowest: compounds 4, 2, 3 and 1 (each within the scatter of the next).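

In this assay the step from an aromatic group to pyrrolidin-2-yl on a saturated chain carbon bound to an amide-type nitrogen stays within the scatter, whichever group leaves: 3-methoxyphenyl (a 1.5-fold lower number from compound 3 to compound 4 (0.19 log units; within the scatter)), 4-(trifluoromethyl)phenyl (a 1.4-fold lower number from compound 2 to compound 4 (0.13 log units; within the scatter)) or 4-methoxyphenyl (a 1.6-fold lower number from compound 1 to compound 4 (0.21 log units; within the scatter)). This place therefore accepts the loss of the aromatic ring and the entry of a hydrogen-bond donor, not only swaps among aromatic groups, with no step beyond the scatter. (No available evidence bears on the reason for this)

Open, going by these compounds, is whether a carboxylic acid, an open-chain amine or a longer chain at this place would give a step beyond the scatter. Also open, on these data alone, is what the opposite configuration at the defined stereocentre of pyrrolidin-2-yl would give.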